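Compound 1 to compound 3: one methyl fewer

The source may hold more compounds than are shown below. What is called first, only, known or untested is meant among the compounds shown, and "the series" means these compounds.

In an ADME assay on Vero 76 cells (Chlorocebus sabaeus) for cytotoxicity, read by MTT assay, with a stated time of 96 h (a lower number here means that less compound is tolerated, a higher number that more compound is tolerated), compound 1 (`Cc1ccc(NCc2cn(-c3ccccc3)nc2-c2ccc(C)cc2)cc1`) gives > 100000 nM, which is a limit and not a number. Compound 2 (`Cc1ccc(NCc2cn(-c3ccccc3)nc2-c2ccccc2)cc1`) gives > 100000 nM, also a limit. The series therefore stands at the limit of > 100000 nM in this assay, at which 2 of the 2 values shown sit.

Compound 3 (`Cc1ccc(-c2nn(-c3ccccc3)cc2CNc2ccccc2)cc1`) changes (4-methylphenyl)amino to anilino, with hydrogen in place of methyl on an aromatic carbon. Among the compounds with values here, the only measured step of this kind, made at another place, is a step that the two limits leave unreadable from compound 1 to compound 2, so it gives no size. No step beyond the scatter is expected in this assay.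

The expected change is a number no higher from compound 1 to compound 3 (the limit leaves the size open). For compound 3 the estimate is 100000 nM, with an expected range of 40000 nM to 100000 nM.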

Compound 3, half-maximal cytotoxic concentration: 52000 nM
Beside the measured number, compound 3's estimate is 1.9-fold (0.28 log units) above it; the measured number falls inside the stated range.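

Compound 3 gives the series its first reading in this assay that is a number and not a limit, so hydrogen in place of methyl on the (4-methylphenyl)amino group now has a step that can be read as a floor: an at least 1.9-fold lower number from compound 1 to compound 3 (0.28 log units; that floor lies within the scatter). The step from compound 1 to compound 2 cannot be read, since both of its ends are limits. The other two compounds stay at the assay's ceiling: the limit of > 100000 nM in this assay, at which 2 of the 3 values shown sit.

On these data alone, the full size of this step stays open. Also open, as far as these compounds go, is whether an amine, a carboxylic acid or a longer chain in place of this methyl would shift the reading beyond the scatter.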